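Replacing dimethylamino with methyl on the shared core

This account rests on a few compounds, and the source may have more. Where it says the series, first, only, none or still open, it means among the compounds named here.

In a functional assay on HCT-116 cells (Homo sapiens), read by MTT assay, with a stated time of 72 h (on this read-out lower numbers stand for stronger inhibition and higher numbers for weaker inhibition), compound 1 `CSc1ncnc2c1c(-c1ccoc1)cn2[C@@H]1O[C@H](CO)[C@@H](O)[C@H]1O` gives 100 nM. Compound 2 `CNc1ncnc2c1c(-c1ccoc1)cn2[C@@H]1O[C@H](CO)[C@@H](O)[C@H]1O` reads > 20000 nM, which is a limit of the assay and not a number. Compound 3 `CN(C)c1ncnc2c1c(-c1ccoc1)cn2[C@@H]1O[C@H](CO)[C@@H](O)[C@H]1O` reads > 20000 nM, which is also only a limit. Compound 3 therefore has no measured number and stands at the limit of > 20000 nM in this assay, at which 2 of the 3 values shown sit. Placing a methyl on the nitrogen gives a step that the two limits leave unreadable from compound 2 to compound 3.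

Compound 4 `Cc1ncnc2c1c(-c1ccoc1)cn2[C@@H]1O[C@H](CO)[C@@H](O)[C@H]1O` has not yet been measured and differs from compound 3 in one place: methyl in place of dimethylamino on an aromatic carbon. Methyl replaces dimethylamino on an aromatic carbon, so the nitrogen group leaves that carbon.

Going by the values given here, two measured steps bear on this change, and both exchange methylsulfanyl for a nitrogen group. Methylamino gives an at least 200-fold higher number from compound 1 to compound 2 (2.30 log units; beyond the scatter), and dimethylamino gives an at least 200-fold higher number from compound 1 to compound 3 (2.30 log units; beyond the scatter). Both are large. Compound 4 reverses part of that exchange, since like compound 1 it has no nitrogen group at this carbon. However, methyl is not methylsulfanyl, and no measured compound carries it, so the recovery may be only partial. The expected change is a large one towards stronger inhibition, an at least 50-fold lower number from compound 3 to compound 4 (1.69 log units; beyond the scatter). For compound 4 the estimated value is 400 nM, with an expected range of 50 nM to 5000 nM.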

Compound 4, half-maximal inhibitory concentration: > 20000 nM
Compound 4 gave a limit, no number; the forecaster's own chance of this, stated with the estimate: 20%; middle value at least 50-fold (1.69 log units) away from the limit.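

In this assay, methyl on this aromatic carbon gives an at least 200-fold higher number from compound 1 to compound 4 (2.30 log units; beyond the scatter), a large step of the same printed size as those to the two nitrogen groups. The earlier loss therefore does not depend on a nitrogen group at this carbon, since a group without nitrogen also fails to restore a measured number, and among the compounds shown only compound 1, with methylsulfanyl, gives one. Compound 4 reads only as a limit, as do compound 2 and compound 3, so the steps among these three cannot be read, and they share one ceiling: the limit of > 20000 nM in this assay, at which 3 of the 4 values shown sit.

The compounds shown leave open whether the sulfur atom or the methylsulfanyl group as a whole matters here, a question that ethylsulfanyl, methoxy or chlorine on this carbon could help to separate. From the compounds shown here alone, how far compound 2, compound 3 and compound 4 lie beyond the limit also remains unknown, so no order among them can be given.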